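A few compounds are considered here, and "the series" means these few. Any claim that something is new, unique, unknown or untested is made for them only; others in the source may bear on it.

In a functional assay on B16-F10 cells (Mus musculus) for antiproliferative activity, read by MTT assay, with a stated time of 72 h (on this read-out lower numbers stand for stronger inhibition and higher numbers for weaker inhibition), compound 1 `CCCCCCCCCNC[C@@H]1OC[C@H](N)[C@H]1O` gives > 128000 nM, which is a limit of the assay and not a number. Among the compounds with values here, compound 2 `CCCCCCCCCCCCCCNC[C@@H]1OC[C@H](N)[C@H]1O`, at 64300 nM, holds the only true number so far. Compound 3 `CCCCCCCCCCCNC[C@@H]1OC[C@H](N)[C@H]1O` differs from it by hydrogen in place of propyl on a saturated chain carbon, ten or more bonds along the chain from an amine nitrogen. Within the data shown here, the one measured step that bears on this is an at least 1.9-fold lower number from compound 1 to compound 2 (0.29 log units; that floor lies within the scatter), whose floor lies within the scatter; it added pentyl where this change removes propyl, so a small rise in the number, near the scatter, is expected in this assay. The expected step is a 1.8-fold higher number from compound 2 to compound 3 (0.25 log units; within the scatter). For compound 3, the estimated value is 115000 nM, with an expected range from 60000 nM to 220000 nM.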

Compound 3, half-maximal inhibitory concentration: 88800 nM
Compound 3: middle estimate off by 1.3-fold (0.11 log units), on the high side, and the stated range covers the measured number.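

Replacing propyl with hydrogen on a saturated chain carbon makes no clear difference in this assay: a 1.4-fold higher number from compound 2 to compound 3 (0.14 log units; within the scatter). Adding ethyl to the chain of compound 1 gives no firm gain either: an at least 1.4-fold lower number from compound 1 to compound 3 (0.15 log units; that floor lies within the scatter). That comparison rests on a limit for compound 1, not a number: the limit of > 128000 nM in this assay, at which 1 of the 3 values shown sits.

The compounds shown leave open whether any change to this chain can move the number beyond the scatter. A longer chain, or a carboxylic acid on the chain, remains an untested question here.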